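This account rests on a few compounds, and the source may have more. Where it says the series, first, only, none or still open, it means among the compounds named here.

In a functional assay on MCF7 cells (Homo sapiens) for cytotoxicity, read by sulforhodamine B assay (a lower number here means that less compound is tolerated, a higher number that more compound is tolerated), compound 1 (`CC1=CC[C@@H]([C@@](C)(O)CCCC(C)(C)NC(=S)N/N=C\c2ccc(C)cc2)CC1`) gives > 100000 nM as a limit of the assay, not a number. Compound 2 (`CC1=CC[C@@H]([C@@](C)(O)CCCC(C)(C)NC(=S)N/N=C\c2ccc([N+](=O)[O-])cc2)CC1`) gives > 100000 nM and this too is a limit. Compound 2 therefore has no readable position, and both compounds stand at the limit of > 100000 nM in this assay, at which 2 of the 2 values shown sit, with no ranking possible. Among the measured compounds shown here, the one measured step, a step that the two limits leave unreadable from compound 1 to compound 2 for nitro in place of methyl on an aromatic carbon, supplies no size to carry forward. Compound 3 (`CC1=CC[C@@H]([C@@](C)(O)CCCC(C)(C)NC(=S)N/N=C\c2cccc(Cl)c2)CC1`) brings the change 3-chlorophenyl in place of 4-nitrophenyl on a carbon with a double bond to nitrogen with 3-chlorophenyl in place of 4-nitrophenyl on a carbon with a double bond to nitrogen. No step beyond the scatter is expected in this assay and another limit is the likeliest report. The expected step is a number no higher from compound 2 to compound 3 (the limit leaves the size open) as an estimate only. For compound 3 the estimated value is 100000 nM with an expected range from 30000 nM to 200000 nM in this assay.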

Compound 3, concentration lethal to 50% of the cells: 45900 nM
Estimate against measurement, compound 3: 2.2-fold (0.34 log units) above, and the stated range covers the measured number.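

In this assay, the group on the carbon with a double bond to nitrogen now proves able to shift the read-out: 3-chlorophenyl in place of 4-nitrophenyl gives an at least 2.1-fold lower number from compound 2 to compound 3 (0.33 log units; beyond the scatter), and 3-chlorophenyl in place of 4-methylphenyl gives an at least 2.1-fold lower number from compound 1 to compound 3 (0.33 log units; beyond the scatter). From the compounds shown here alone, both steps are minimum sizes, so the full size of each remains unknown. Compound 3 is the only one of the series with a measured number, while compound 1 and compound 2 remain at a limit of the assay: the limit of > 100000 nM in this assay, at which 2 of the 3 values shown sit.

The compounds shown do not separate the effect of chlorine from that of its ring position, a question that 4-chlorophenyl would address. Going by these compounds, the outcome with an amine or a carboxylic acid on the phenyl ring also remains open.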